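Shrinking a Benzofuran to a Furan on a Nucleoside Core

The source may report more compounds than this note shows. Statements on the series, on what has been measured and on what is new or still open speak of the compounds shown alone.

Compound 1 `Nc1nc(N)c2c(-c3ccsc3)cn([C@@H]3O[C@H](CO)[C@@H](O)[C@H]3O)c2n1`: > 20000 nM
Compound 2 `COc1nc(N)nc2c1c(-c1cc3ccccc3o1)cn2[C@@H]1O[C@H](CO)[C@@H](O)[C@H]1O`: 14600 nM
Compound 3 `Nc1nc(N)c2c(-c3cc4ccccc4o3)cn([C@@H]3O[C@H](CO)[C@@H](O)[C@H]3O)c2n1`: 18600 nM

In a functional assay on K562 cells (Homo sapiens), read by MTT assay, with a stated time of 72 h (a lower number here means a stronger inhibitor, a higher number a weaker inhibitor), compound 3 gives 18600 nM, the higher of the two plain numbers shown. Its neighbour is compound 2, and the step of a 1.3-fold higher number from compound 2 to compound 3 (0.11 log units; within the scatter) lies within the scatter. For compound 1 the assay reports only a limit, > 20000 nM, namely (the limit of > 20000 nM in this assay, at which 1 of the 3 values shown sits).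

Compound 4 `Nc1nc(N)c2c(-c3ccoc3)cn([C@@H]3O[C@H](CO)[C@@H](O)[C@H]3O)c2n1` differs from compound 3 by furan-3-yl in place of 1-benzofuran-2-yl on an aromatic carbon. Among the measured compounds shown here, the one step that bears on this is an at least 1.0-fold lower number from compound 1 to compound 3 (0.03 log units; that floor lies within the scatter), where a small five-membered ring stands at the floor of the assay while the larger bicyclic ring gives a weak but measurable number. Compound 4 is therefore expected to be weak, estimated at 25000 nM with a range of 10000 nM to 60000 nM, a step of a 1.3-fold higher number from compound 3 to compound 4 (0.13 log units; within the scatter), most likely reported only as a limit.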

Compound 4, half-maximal inhibitory concentration: > 20000 nM
Compound 4 ended at the assay's limit (the forecaster's own chance of this, stated with the estimate: 60%); the middle value is on the limit's open side.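

In this assay compound 4 joins compound 1 at the assay's limit, so two small five-membered rings at this position now give no plain number, whereas 1-benzofuran-2-yl in compound 3 does. Trimming the ring system to furan-3-yl gives an at least 1.0-fold higher number from compound 3 to compound 4 (0.03 log units; that floor lies within the scatter), so no real loss of activity can be claimed. The step between compound 1 and compound 4 cannot be read, as the two limits leave it open: the limit of > 20000 nM in this assay, at which 2 of the 4 values shown sit.

As far as these compounds go, whether the two small rings truly differ stays open. So does whether an amine or a carboxylic acid at this position would give a lower number.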